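The source may report more compounds than this note shows. Statements on the series, on what has been measured and on what is new or still open speak of the compounds shown alone.

Measured so far in a functional assay on LOX IMVI cells (Homo sapiens) for cytotoxicity, read by MTT assay, with a stated time of 24 h; on this read-out lower numbers stand for stronger inhibition and higher numbers for weaker inhibition:

- Compound 1 `COc1cc(-c2nc(-c3ccccc3)[nH]c2-c2ccnc(NCCCNS(=O)(=O)c3ccc(Cl)cc3)n2)ccc1Cl`: 60900 nM
- Compound 2 `O=S(=O)(NCCCNc1nccc(-c2[nH]c(-c3ccccc3)nc2-c2ccc(Cl)c(O)c2)n1)c1ccccc1`: 2630 nM

Of these two, compound 2 has the lower number, which makes it the more potent in this assay. The gap between it and compound 1 is larger than the usual scatter of repeated measurements.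

The next compound to consider is compound 3 `O=S(=O)(NCCCNc1nccc(-c2[nH]c(-c3ccccc3)nc2-c2ccc(Cl)c(O)c2)n1)c1ccc(Cl)cc1`, which differs from compound 2 in a single place: chloro in place of hydrogen on an aromatic carbon. Chloro takes the place of hydrogen on an aromatic carbon, para to a large group, so phenylsulfonyl becomes (4-chlorophenyl)sulfonyl. Among the measured compounds shown here, no measured pair in this small set shows that change on its own, so the data give no direct size for it. The expectation is therefore cautious: no step beyond the scatter, in either direction, with a wide margin for error. Resting on compound 2 at 2630 nM, the estimated step is a 1.1-fold higher number from compound 2 to compound 3 (0.06 log units; within the scatter). For compound 3 the estimated value is 3000 nM, with an expected range of 900 nM to 10000 nM.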

Compound 3, half-maximal inhibitory concentration: 61300 nM
Compound 3: middle estimate off by 20-fold (1.31 log units), on the low side, and the stated range ends below it.
By their numbers in this assay, from the lowest: compound 2; then compounds 1 and 3 (each within the scatter of the next).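

In this assay this place on the phenylsulfonyl group proves highly sensitive: a single chlorine para to a large group, turning phenylsulfonyl into (4-chlorophenyl)sulfonyl, gives a 23-fold higher number from compound 2 to compound 3 (1.37 log units; beyond the scatter) and so removes most of the potency of the more potent parent. With (4-chlorophenyl)sulfonyl present, hydrogen in place of methyl on an oxygen on an aromatic ring gives a 1.0-fold higher number from compound 1 to compound 3 (0.00 log units; within the scatter) and so makes no difference that can be told from the scatter, which places the earlier gap between compound 1 and compound 2 on the chloro rather than on the methyl. Nothing measured here bears on why one chlorine has so large an effect at this place.

On these data alone, it stays open whether a fluoro, a methyl or a methoxy at this place would give a step of similar size, or whether the loss is particular to chloro. As far as these compounds go, it is also open whether hydrogen and methyl on that oxygen would remain this close on a plain phenylsulfonyl, where the chloro is absent and the potency is higher.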